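Amino substitution on the benzyl arm of compound 1

This account rests on a few compounds, and the source may have more. Where it says the series, first, only, none or still open, it means among the compounds named here.

Among the compounds with values here, compound 1 `COc1cccc(CNCc2c(C(=O)O)n(Cc3ccccc3)c3cc(C(C)C)ccc23)c1` gives 4110 nM in a functional assay on Hep 3B2 cells (Homo sapiens) for antiproliferative activity, read by MTT assay, with a stated time of 72 h (a higher number here means a weaker inhibitor, a lower number a stronger inhibitor), the lowest of the three numbers known so far. Compound 2 `COc1ccc(Cn2c(C(=O)O)c(CNCc3cccc(O)c3)c3ccc(C(C)C)cc32)cc1` gives 6600 nM in this assay, which sits within the scatter of compound 1, so nothing separates the two. Compound 3 `COc1cccc(CNCc2c(C(=O)O)n(Cc3ccc(C)cc3)c3ccccc23)c1` gives 14500 nM in this assay, a gap from compound 1 that lies beyond the scatter. Within the data shown here, no step between measured compounds differing in a single place is known, so the effect of a lone change cannot be read from the series. Compound 4 `COc1cccc(CNCc2c(C(=O)O)n(Cc3ccc(N)cc3)c3cc(C(C)C)ccc23)c1` differs from compound 1 by amino in place of hydrogen on an aromatic carbon, taking benzyl to 4-aminobenzyl. The step of a 1.1-fold higher number from compound 1 to compound 4 (0.04 log units; within the scatter) is expected to be small, not beyond the scatter in either direction. Compound 4 is expected to give 4500 nM, within 1800 nM to 11000 nM.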

Compound 4, half-maximal inhibitory concentration: 11300 nM
Compound 4: middle estimate off by 2.5-fold (0.40 log units), on the low side; the whole stated range lies below it.
By their numbers in this assay, from the lowest: compounds 1, 2, 4 and 3 (each within the scatter of the next, the first and the last beyond it).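

The series now has its first single-place step: amino in place of hydrogen on an aromatic carbon, para to a large group, gives a 2.7-fold higher number from compound 1 to compound 4 (0.44 log units; beyond the scatter) in this assay. This position is therefore not indifferent to substitution, and the change from benzyl to 4-aminobenzyl modestly weakens the compound. No measurement in hand accounts for this step.

Going by these compounds, whether a chlorine or a dimethylamino group at this position would shift the number in the same direction remains open. Also open, on these data alone, is whether an acetamide would recover the value of compound 1.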